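Trading a Propyl Tail for Chlorine on the Amide Chain

The source may report more compounds than this note shows. Statements on the series, on what has been measured and on what is new or still open speak of the compounds shown alone.

For the measured compounds named here, compound 3 `CCCCCC(=O)Nc1ccc(S(=O)(=O)Oc2ccccc2I)cc1` gives 10000 nM in a functional assay on MCF7 cells (Homo sapiens) for antiproliferative activity, read by sulforhodamine B assay, with a stated time of 48 h (on this read-out higher numbers stand for weaker inhibition and lower numbers for stronger inhibition), and stands second highest among the three numbers measured so far. Its nearest neighbour on this scale, compound 1 `CC(C)C(=O)Nc1cccc(S(=O)(=O)Oc2ccccc2C(C)C)c1`, gives 13000 nM, while compound 2 `CCCCCC(=O)Nc1ccc(S(=O)(=O)Oc2ccccc2C(C)C)cc1` gives 5300 nM. The only single-point step among these, a 1.9-fold higher number from compound 2 to compound 3 (0.28 log units; within the scatter), concerns the group on the aromatic carbon and says nothing about the amide chain.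

Compound 4 `O=C(CCCl)Nc1ccc(S(=O)(=O)Oc2ccccc2I)cc1` differs from compound 3 precisely in that chain: chloro in place of propyl on a saturated chain carbon, two bonds along the chain from a carbonyl carbon. Going by the values given here, no measured step touches this part of the molecule, so no direct guide exists. Compound 1 and compound 2 differ in their chains, but they also differ elsewhere, so the chain's share of the gap between their values cannot be separated out. Compound 4 is therefore expected to show a 1.2-fold higher number from compound 3 to compound 4 (0.08 log units; within the scatter), a shift that stays within the scatter. The estimate for compound 4 in this assay is 12000 nM, within a range from 5000 nM to 30000 nM.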

Compound 4, half-maximal inhibitory concentration: 8900 nM
Compound 4: the middle estimate sits 1.3-fold (0.13 log units) above what was measured; low and high end bracket the measured number.
By their numbers in this assay, from the lowest: compounds 2, 4, 3 and 1 (each within the scatter of the next, the first and the last beyond it).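

In this assay, putting chloro in place of propyl on a saturated chain carbon, two bonds along the chain from a carbonyl carbon, gives a 1.1-fold lower number from compound 3 to compound 4 (0.05 log units; within the scatter) and is the first change shown that touches the amide chain alone. For this pair, then, pentyl can give way to 2-chloroethyl without moving the number beyond the usual scatter, so the read-out does not separate the two chains. Nothing available gives a reason for this outcome.

From the compounds shown here alone, whether an amine, a carboxylic acid or a longer chain at this same place would move the number beyond the scatter remains open. Also open, going by these compounds, is whether the same change would give so small a step with the isopropyl of compound 2 in place of the iodo of compound 3.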